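This account rests on a few compounds, and the source may have more. Where it says the series, first, only, none or still open, it means among the compounds named here.

Compound 1 `O=S(=O)(c1ccccc1)c1cn(C2CCNCC2)c2ccccc12`: 91 nM
Compound 2 `COc1ccc2c(c1)c(S(=O)(=O)c1cccc(F)c1)cn2C1CCCNC1`: 10.7 nM
Compound 3 `O=S(=O)(c1cccc(F)c1)c1cn(C2CCCNC2)c2ccc(F)cc12`: 4 nM

In an assay on HeLa cells for displacement of a labelled ligand from 5-hydroxytryptamine receptor 6 (Homo sapiens), with a stated time of 2 h (a lower number here means a stronger inhibitor, a higher number a weaker inhibitor), compound 3 stands lowest of the three. Among the compounds with values here, the one measured single-place step, a 2.7-fold lower number from compound 2 to compound 3 (0.43 log units; beyond the scatter), separates it from its nearest neighbour; the furthest, compound 1, gives 91 nM and differs from compound 3 in more than one place, so no single step is known between them. Compound 4 `O=S(=O)(c1cccc(F)c1)c1cn(C2CCNC2)c2ccc(F)cc12` carries pyrrolidin-3-yl in place of piperidin-3-yl on an aromatic nitrogen. Within the data shown here, no measured step concerns this change: the only known step involves an aromatic carbon, not the group on the aromatic nitrogen. A step of modest size, in either direction, is therefore expected in this assay. Compound 4 is estimated at 8 nM, within 2.5 nM to 25 nM, which would mean a 2.0-fold higher number from compound 3 to compound 4 (0.30 log units; within the scatter).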

Compound 4, inhibition constant: 9.6 nM
Beside the measured number, compound 4's estimate is 1.2-fold (0.08 log units) below it; measured number inside the range.
By their numbers in this assay, from the lowest: compound 3; then compounds 4 and 2 (each within the scatter of the next); then compound 1.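

In this assay, within the data shown here, the measured series shows a 2.4-fold higher number from compound 3 to compound 4 (0.38 log units; beyond the scatter) for pyrrolidin-3-yl in place of piperidin-3-yl on the aromatic nitrogen, the first single-place step at this position, as the only earlier step concerned an aromatic carbon. The position therefore responds, modestly but beyond the scatter, to a five-membered ring replacing a six-membered one, and the six-membered ring of compound 3 gives the lower number. Nothing available explains this step.

The compounds shown leave open how an azetidin-3-yl ring or an open aminoethyl chain would read at this position.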